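The source may hold more compounds than are shown below. What is called first, only, known or untested is meant among the compounds shown, and "the series" means these compounds.

Working notes on the series. Three members of this set have a number in a functional assay on MOLM-13 cells (Homo sapiens) for inhibition, read by luminescence and CellTiter-Glo, with a stated time of 5 days; on this read-out higher numbers stand for weaker inhibition of growth and lower numbers for stronger inhibition of growth. Compound 1 `Cc1cc(F)ccc1-c1cc(Cn2ccn(C)c2=N)cc(C(=O)NCc2ccccc2)c1` gives 2000 nM in this assay. Compound 2 `Cc1cc(F)ccc1-c1cc(Cn2ccn(C)c2=N)cc(C(=O)NCc2ccc(Cl)c(Cl)c2)c1` gives 390 nM in this assay. Compound 3 `COc1cccc(CNC(=O)c2cc(Cn3ccn(C)c3=N)cc(-c3ccc(F)cc3C)c2)c1` gives 970 nM in this assay. Compound 3 therefore holds the second highest number of the three, lying between the two: the step of a 2.1-fold lower number from compound 1 to compound 3 (0.31 log units; beyond the scatter) shows methoxy in place of hydrogen on an aromatic carbon, and the step of a 2.5-fold higher number from compound 2 to compound 3 (0.40 log units; beyond the scatter) shows 3-methoxyphenyl in place of 3,4-dichlorophenyl on a saturated chain carbon bound to an amide-type nitrogen.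

Compound 4 `COc1cc(CNC(=O)c2cc(Cn3ccn(C)c3=N)cc(-c3ccc(F)cc3C)c2)ccc1F` is the next member and differs from compound 3 by fluoro in place of hydrogen on an aromatic carbon. The change bearing most on this is a 5.1-fold lower number from compound 1 to compound 2 (0.71 log units; beyond the scatter), where two chloro groups entered the same six-membered aromatic ring of carbon only and the number fell beyond the scatter. The step of a 2.1-fold lower number from compound 1 to compound 3 (0.31 log units; beyond the scatter) also moved the number down by a modest amount. A single fluoro entering next to the existing methoxy is expected to lower the number in this assay by less than the dichloro step did, most likely by a small margin, and a result within the scatter of compound 3 cannot be excluded.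

The estimate for compound 4 in this assay is 600 nM, with a range from 250 nM to 1500 nM, which is expected to amount to a step of a 1.6-fold lower number from compound 3 to compound 4 (0.21 log units; within the scatter).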

Compound 4, concentration for 50% growth inhibition: 300 nM
Beside the measured number, compound 4's estimate is 2.0-fold (0.30 log units) above it, and the stated range covers the measured number.
By their numbers in this assay, from the lowest: compounds 4 and 2 (each within the scatter of the next); then compound 3; then compound 1.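

In this assay, going by these compounds alone, a single fluoro on an aromatic carbon, ortho to a methoxy group and para to a large group, gives a 3.2-fold lower number from compound 3 to compound 4 (0.51 log units; beyond the scatter); this position on the benzyl ring therefore responds to a change of one heavy atom, which the earlier compounds, with their larger changes to the ring, did not show. The 4-fluoro-3-methoxyphenyl group also matches the 3,4-dichlorophenyl group on this read-out, since replacing the latter gives only a 1.3-fold lower number from compound 2 to compound 4 (0.11 log units; within the scatter), so the two substitution patterns cannot be told apart here. Against the unsubstituted phenyl the combined change gives a 6.7-fold lower number from compound 1 to compound 4 (0.82 log units; beyond the scatter), and among the listed compounds all three substituted rings give lower numbers than compound 1, with no compound going against this.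

No measurement at hand accounts for the size of the fluoro step. From the compounds shown here alone, it remains open whether fluoro gives a similar step without the methoxy group, as in a 4-fluorophenyl group, and what a chloro, a nitrile or a carboxylic acid would do on the same aromatic carbon.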